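Ortho-substituted aryl imidazole bicycles: agonism at the alpha-1D receptor

The source may hold more compounds than are shown below. What is called first, only, known or untested is meant among the compounds shown, and "the series" means these compounds.

Measured compounds:
compound 1 `FC(F)Oc1ccccc1C1Cc2nccn2C1`, "not determined" (no result reported)
compound 2 `COc1cccc(C2Cc3nccn3C2)c1`, > 10000 nM
compound 3 `c1ccc(C2CCc3nc[nH]c3C2)cc1`, > 10000 nM; > 10000 nM; > 10000 nM (3 entries)

The set is read in a functional assay on CHO cells for agonist activity at Alpha-1D adrenergic receptor (Homo sapiens), read by FLIPR and calcium flux; a lower number here means that less compound is needed, a higher number that more compound is needed for the effect. For compound 1 no result is reported in this assay. Compound 2 gives only a limit in this assay, > 10000 nM, not a number. Compound 3 likewise sits at a limit in all three of its entries, > 10000 nM; > 10000 nM; > 10000 nM (3 entries). From the compounds shown here alone, the only firm point on the scale is therefore (the limit of > 10000 nM in this assay, at which 1 of the 3 values shown sits), and compound 1 stands nowhere on it: its own standing is unknown, and the two compounds that share its core and bear a different aryl group both return limits.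

Compound 4 `N#Cc1ccccc1C1Cc2nccn2C1` is the next compound. It differs from compound 1 in one place: cyano in place of difluoromethoxy on an aromatic carbon. Among the compounds with values here, no step between measured compounds is available, so the size and direction of the change cannot be read from the data; with no number for compound 1, no step beyond scatter can be expected in this assay in either direction. Given that compound 2 and compound 3 both reach only a limit, compound 4 is expected to give about 10000 nM in this assay, in the range 2000 nM to 50000 nM, most likely again as a limit.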

Compound 4, half-maximal effective concentration: > 10000 nM
Compound 4: no number, only a limit; the forecaster's own chance of this, stated with the estimate: 70%; the middle value lies on the limit itself.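

Compound 4 sits at a limit, > 10000 nM, not a number. Compound 1 has no number either, so no step can be read between compound 1 and compound 4. The compounds shown leave open whether any aryl substituent on the shared core reaches a measurable value in this assay.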